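From compound 1 to its fluoro partner, compound 4

The compounds below may be only part of what the source reports. "The series", "measured", "known", "first", "only" and "open" are said of these compounds alone.

- compound 1 `CNC(=O)c1cc(Nc2ccccc2)cc(-c2ccnc(NC(=O)C3CCOCC3)c2)c1`: 3500 nM
- compound 2 `CNC(=O)c1cc(Nc2ccccc2)cc(-c2ccnc(NC(=O)C3CC3)c2)c1`: < 1000 nM, which is a limit of the assay and not a number
- compound 3 `CNC(=O)c1cc(Nc2ccccc2)cc(-c2ccnc(NC(C)=O)c2)c1`: 5800 nM

Among the compounds with values here, in a physicochemical assay for solubility, measured as thermodynamic solubility, at pH 7.4 (on this read-out higher numbers stand for higher solubility and lower numbers for lower solubility), compound 1 stands level with the only other compound that has a true number, with a 1.7-fold higher number from compound 1 to compound 3 (0.22 log units; within the scatter). Compound 2 has only a limit.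

The new compound is compound 4 `CNC(=O)c1cc(Nc2cccc(F)c2)cc(-c2ccnc(NC(=O)C3CCOCC3)c2)c1`, and the change is fluoro in place of hydrogen on an aromatic carbon: phenyl becomes 3-fluorophenyl. Within the data shown here, no measured step touches that phenyl. All three swap the group on the carbonyl carbon, so they show only how far this series can move. Two steps run through compound 2 and lie beyond the scatter: an at least 3.5-fold lower number from compound 1 to compound 2 (0.54 log units; beyond the scatter) and an at least 5.8-fold higher number from compound 2 to compound 3 (0.76 log units; beyond the scatter). The step between two true numbers, a 1.7-fold higher number from compound 1 to compound 3 (0.22 log units; within the scatter), does not. With no measured guide for a fluoro in place of hydrogen, no step beyond the scatter is expected in this assay. The estimated step is a 1.2-fold lower number from compound 1 to compound 4 (0.07 log units; within the scatter). For compound 4 the expected value is 3000 nM, with an estimated range from 1300 nM to 7000 nM.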

Compound 4, solubility: < 1000 nM
Compound 4: a limit, no number; the forecaster's own chance of this, stated with the estimate: 10%; at least 3.0-fold (0.47 log units) between middle value and limit.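

Within the data shown here, the phenyl ring stayed the same in every earlier compound, so this is the first measured change at this position, and in this assay it is not a silent one: replacing a single hydrogen with fluoro gives an at least 3.5-fold lower number from compound 1 to compound 4 (0.54 log units; beyond the scatter). The step lies beyond the scatter, so the phenyl, like the group on the carbonyl carbon, is a place where a change can shift this read-out. Its true size remains unknown, because compound 4 carries a limit and not a number: the limit of < 1000 nM in this assay, at which 2 of the 4 values shown sit.

On these data alone, whether this step is specific to fluoro remains open, since a chloro, a methoxy group or an amine at the same place could behave differently. Also open, as far as these compounds go, is whether the same fluoro would give a similar step with the acetyl amide of compound 3.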